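Swapping One Ring on a Short-Lived Compound

A few compounds are considered here, and "the series" means these few. Any claim that something is new, unique, unknown or untested is made for them only; others in the source may bear on it.

So far, three compounds have been measured in an in vitro ADME assay on microsomes from liver (Homo sapiens) for metabolic stability; on this read-out higher numbers stand for a longer-lived compound and lower numbers for a shorter-lived compound. Compound 3 `Cc1cccc(CNC(=O)C2CCCN(Cc3nc(-c4ccccc4)oc3C)C2)n1` gives 0.096 h. Going by the values given here, compound 1 `COC[C@@H]1C[C@@H](C(=O)NC[C@H]2CCCO2)CN(Cc2nc(-c3ccccc3)oc2C)C1` gives 0.07 h, a value within the scatter of the one for compound 3. Compound 2 `Cc1cccc(CNC(=O)[C@H]2C[C@H](c3nc(C)no3)CN(Cc3nc(-c4ccccc4)oc3C)C2)n1` is reported only as a limit, < 0.05 h.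

Compound 4 `Cc1oc(-c2ccccc2)nc1CN1CCCC(C(=O)NCC2CCOCC2)C1` has not yet been measured in this assay. It differs from compound 3 in one place, with oxan-4-yl in place of 6-methylpyridin-2-yl on a saturated chain carbon bound to an amide-type nitrogen. The exchange keeps the count of hydrogen-bond acceptors and leaves no net charge on either group. Among the compounds with values here, no measured pair of compounds isolates this exchange, so the data give no direct size for it. The expectation therefore starts from compound 3 at 0.096 h, and no change beyond the scatter is anticipated. The expected step of a 1.1-fold higher number from compound 3 to compound 4 (0.06 log units; within the scatter) is small and could go in either direction. For compound 4 the estimated half-life is 0.11 h, with an expected range from 0.05 h to 0.3 h.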

Compound 4, half-life: 0.156 h
Beside the measured number, compound 4's estimate is 1.4-fold (0.15 log units) below it; measured number inside the range.
By their numbers in this assay, from the lowest: compounds 1, 3 and 4 (each within the scatter of the next, the first and the last beyond it). At a limit, below all of these: compound 2.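

Going by these compounds alone, this is the first exchange that can be read in one place: in this assay, oxan-4-yl in place of 6-methylpyridin-2-yl on a saturated chain carbon bound to an amide-type nitrogen gives a 1.6-fold higher number from compound 3 to compound 4 (0.21 log units; within the scatter). The six-membered aromatic ring at this place can therefore give way to a six-membered non-aromatic ring with one hetero atom without a change beyond the scatter, so this single exchange does not show a real gain in half-life, and the pair remains short-lived on this read-out. Compound 2 is reported only as a limit and not as a number, so it gives no size for any step: the limit of < 0.05 h in this assay, at which 1 of the 4 values shown sits.

The compounds shown leave open whether a group of a different kind on this same carbon, such as a carboxylic acid, an amine or a longer chain ending in a hydroxyl group, would move the half-life beyond the scatter. They also leave open whether any exchange at this place can do so, or whether a change elsewhere in the shared core would be needed to lengthen the half-life.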